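The compounds below may be only part of what the source reports. "The series", "measured", "known", "first", "only" and "open" are said of these compounds alone.

Three compounds have been measured in a functional assay on HTB-54 cells (Homo sapiens) for cytotoxicity, read by MTT assay, with a stated time of 72 h; a higher number here means a weaker inhibitor of growth, a lower number a stronger inhibitor of growth:

Compound 1, `COc1ccc(OC(=O)Nc2ccc([Se]C#N)cc2)cc1`, gives 23700 nM.
Compound 2, `CC(C)COC(=O)Nc1ccc([Se][Se]c2ccc(NC(=O)OCC(C)C)cc2)cc1`, gives 29000 nM.
Compound 3, `C=CCOC(=O)Nc1ccc([Se]C#N)cc1`, gives 27000 nM.

Compound 1 has the lowest of these three numbers, but its gap to compound 3 and its gap to compound 2 both lie within the usual scatter, so the three results cannot be told apart. Compound 4, `N#C[Se]c1ccc(NC(=O)Oc2ccc(F)cc2)cc1`, differs from compound 1 by fluoro in place of methoxy on an aromatic carbon. For the measured compounds named here, no measured pair shows what this change does. Going by the values given here, since the three known numbers sit close together, no step beyond the scatter is expected in this assay. Compound 4 is expected to give about 24000 nM, within a range from 10000 nM to 55000 nM. The expected step of a 1.0-fold higher number from compound 1 to compound 4 (0.01 log units; within the scatter) is thus estimated to stay within the scatter.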

Compound 4, concentration for 50% growth inhibition: 25000 nM
Compound 4: middle estimate off by 1.0-fold (0.02 log units), on the low side; the range from low to high includes it.
By their numbers in this assay, from the lowest: compounds 1, 4, 3 and 2 (each within the scatter of the next).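

Exchanging methoxy for fluoro on this aromatic carbon, para to a large group, gives a 1.1-fold higher number from compound 1 to compound 4 (0.02 log units; within the scatter) in this assay. The position therefore accepts this swap without a measurable change in growth inhibition, although fluoro has fewer heavy atoms than methoxy and, unlike methoxy, counts no hydrogen-bond acceptor. No measurement bears on why the number holds steady. Still open, going by these compounds, is whether a different kind of group here, such as an amine or a carboxylic acid, would shift the number beyond the scatter.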